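The compounds below may be only part of what the source reports. "The series", "measured", "known", "first", "only" and "open" are said of these compounds alone.

Among the measured compounds shown here, in a functional assay on HepG2 cells (Homo sapiens) for inhibition, read by MTT assay, with a stated time of 48 h (on this read-out higher numbers stand for weaker inhibition and lower numbers for stronger inhibition), compound 1, `O=C(Nc1cccc(Cl)c1)Nc1ccc(-c2cc(=O)c3ccccc3o2)c(Cl)c1`, gives 9700 nM, the lower of the two numbers measured so far, and compound 2, `COc1ccc2oc(-c3ccc(NC(=O)Nc4cccc(Cl)c4)cc3Cl)cc(=O)c2c1`, gives 26300 nM. Compound 3, `O=C(Nc1cccc(Cl)c1)Nc1ccc(-c2cc(=O)c3ccc(O)cc3o2)c(Cl)c1`, has hydroxy in place of hydrogen on an aromatic carbon of the core of compound 1: hydroxy in place of hydrogen on an aromatic carbon. For the measured compounds named here, only one measured step bears on this change, the swap of methoxy for hydrogen on an aromatic carbon. This step, a 2.7-fold higher number from compound 1 to compound 2 (0.43 log units; beyond the scatter), is modest but beyond the scatter. It involves a different group, so it is only a loose guide. A small rise in the number, meaning slightly weaker inhibition, is the likeliest outcome, and a change within the scatter would be no surprise. The expected step is a 1.3-fold higher number from compound 1 to compound 3 (0.13 log units; within the scatter). For compound 3 the estimated value is 13000 nM, with an expected range from 4500 nM to 35000 nM.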

Compound 3, half-maximal inhibitory concentration: 12200 nM
For compound 3 the middle estimate is 1.1-fold (0.03 log units) above the measured one; the range from low to high includes it.
By their numbers in this assay, from the lowest: compounds 1 and 3 (each within the scatter of the next); then compound 2.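

In this assay, hydroxy in place of hydrogen on this aromatic carbon of the core gives a 1.3-fold higher number from compound 1 to compound 3 (0.10 log units; within the scatter), so compound 1 and compound 3 cannot be told apart. Among the compounds shown here, this is the first direct reading for hydroxy: a group with one oxygen, bringing a hydrogen-bond donor and a hydrogen-bond acceptor, can sit on this carbon with a number inside the scatter of the parent compound. No measurement shown here explains this result.

A single small group on one carbon cannot show how much room for change this position has overall. On these data alone, whether a larger or differently charged group here, such as an amine or a carboxylic acid, would also leave the number within the scatter remains open.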